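A few compounds are considered here, and "the series" means these few. Any claim that something is new, unique, unknown or untested is made for them only; others in the source may bear on it.

Compound 1, `N#Cc1cc(C#N)cc(-n2nnc(-c3ccccn3)n2)c1` — 34 nM in a functional assay with metabotropic glutamate receptor 5 (Rattus norvegicus) as the target; a lower number here means a stronger inhibitor, a higher number a weaker inhibitor
Compound 2, `N#Cc1cc(-n2nnc(-c3ccccn3)n2)cc([N+](=O)[O-])c1` — 42 nM in this assay
Compound 3, `COc1cc(C#N)cc(-n2nnc(-c3ccccn3)n2)c1` — 10 nM in this assay

The three measured compounds share one core and differ only in the group that sits on the outer benzene ring alongside the nitrile. Compound 1 and compound 2 lie close together: the step of a 1.2-fold higher number from compound 1 to compound 2 (0.09 log units; within the scatter) is within the scatter, so the two values cannot be ordered. Compound 3 stands apart as the most potent of the three, with the lowest number in this assay; its nearest neighbour is compound 1, and the steps of a 3.4-fold lower number from compound 1 to compound 3 (0.53 log units; beyond the scatter) and a 4.2-fold lower number from compound 2 to compound 3 (0.62 log units; beyond the scatter) are both beyond the scatter, though modest in size.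

Compound 4, `N#Cc1cc(N)cc(-n2nnc(-c3ccccn3)n2)c1`, takes this one step further: amino in place of methoxy on an aromatic carbon. Neither of the measured steps tests an amino group; both only show that the methoxy gives a lower number than a cyano or a nitro group. What they tell about an amino group is therefore indirect. The estimate for compound 4 is anchored on compound 3 and allowed to drift back towards compound 1, with the step of a 2.0-fold higher number from compound 3 to compound 4 (0.30 log units; within the scatter) expected to stay close to the scatter. Compound 4 is thus expected to give about 20 nM in this assay, within a range of 6 nM to 70 nM.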

Compound 4, half-maximal inhibitory concentration: 308 nM
Beside the measured number, compound 4's estimate is 15-fold (1.19 log units) below it, and the stated range ends below it.
By their numbers in this assay, from the lowest: compound 3; then compounds 1 and 2 (each within the scatter of the next); then compound 4.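

The first three compounds left this position looking fairly forgiving, since methoxy, nitrile and nitro differed only modestly, but amino shows that a single exchange here can cost a large amount of potency in this assay (a 31-fold higher number from compound 3 to compound 4 (1.49 log units; beyond the scatter)). The change is small by count, with 1 heavy atom of nitrogen replacing 2 heavy atoms of carbon and oxygen and 1 hydrogen-bond donor entering where methoxy has 0, yet compound 4 is also clearly separated from the nitrile and nitro compounds (a 9.1-fold higher number from compound 1 to compound 4 (0.96 log units; beyond the scatter) and a 7.3-fold higher number from compound 2 to compound 4 (0.87 log units; beyond the scatter)), so amino is the least favourable of the four groups shown. Nothing available here accounts for this rise in the number.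

On these data alone, whether the loss follows the amino hydrogens remains open, since a dimethylamino group or a hydroxyl group at this position could fall nearer to either compound 3 or compound 4. As far as these compounds go, it is equally open whether an ethoxy group or a longer ether chain would hold or improve on the methoxy group of compound 3.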